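The source may hold more compounds than are shown below. What is called first, only, known or untested is meant among the compounds shown, and "the series" means these compounds.

Measured so far in a functional assay on HOS cells (Homo sapiens) for antiproliferative activity, read by sulforhodamine B assay; a lower number here means a stronger inhibitor of growth, a higher number a weaker inhibitor of growth:
- Compound 1 `O[C@H]1CO[C@H](COCc2ccccc2)[C@@H](OCc2ccccc2)[C@@H]1OCc1ccccc1`: 37900 nM
- Compound 2 `OCCC[C@@H]1O[C@H](COCc2ccccc2)[C@@H](OCc2ccccc2)[C@H](OCc2ccccc2)[C@H]1O`: > 50000 nM, a limit of the assay and not a number

Compound 2 has no number of its own and rests on (the limit of > 50000 nM in this assay, at which 1 of the 2 values shown sits). Compound 3 `O[C@@H]1[C@@H](OCc2ccccc2)[C@H](OCc2ccccc2)[C@@H](COCc2ccccc2)O[C@H]1CC1CC1` differs from it as follows: cyclopropyl in place of 2-hydroxyethyl on a saturated chain carbon bound to a saturated ring carbon. Cyclopropyl thus stands in place of 2-hydroxyethyl on a saturated chain carbon bound to a saturated ring carbon. Cut one bond further out, the change reads 3-hydroxypropyl to cyclopropylmethyl.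

For the measured compounds named here, only one measured step bears on this, the one that put 3-hydroxypropyl in place of hydrogen on a saturated ring carbon: an at least 1.3-fold higher number from compound 1 to compound 2 (0.12 log units; that floor lies within the scatter). Going by the values given here, it gives only a floor, and no measured step replaces 3-hydroxypropyl with another group. No step beyond the scatter is therefore expected in this assay, and compound 3 should stay a weak inhibitor of growth, in the region of compound 1 at 37900 nM. The estimated change is an at least 1.2-fold lower number from compound 2 to compound 3 (0.09 log units; that floor lies within the scatter). The expected value for compound 3 is 40000 nM, with an estimated range of 15000 nM to 70000 nM.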

Compound 3, concentration for 50% growth inhibition: > 50000 nM
Compound 3 ended at the assay's limit (the forecaster's own chance of this, stated with the estimate: 40%); middle value at least 1.2-fold (0.09 log units) away from the limit.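

In this assay, cyclopropylmethyl in place of hydrogen on a saturated ring carbon gives an at least 1.3-fold higher number from compound 1 to compound 3 (0.12 log units; that floor lies within the scatter), so this second group, like 3-hydroxypropyl, yields only a floor that lies within the scatter. Compound 2 and compound 3 both stand at a limit of the assay and not at a number, and the step between them, cyclopropyl in place of 2-hydroxyethyl on a saturated chain carbon, cannot be read. The new result therefore adds a second substituent without a hydrogen-bond donor at this place, and it still gives no number, which leaves the comparison of the two groups capped: the limit of > 50000 nM in this assay, at which 2 of the 3 values shown sit.

Going by these compounds, it remains open how far compound 2 and compound 3 lie beyond that limit, and so whether either really differs from compound 1 by more than the scatter. On these data alone, it also remains open whether an amine, a carboxylic acid or a longer chain on the same saturated ring carbon would bring a value back inside the range of this assay.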